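From Cyclopropylmethoxy to Phenoxy on a Shared Core

The source may hold more compounds than are shown below. What is called first, only, known or untested is meant among the compounds shown, and "the series" means these compounds.

Going by the values given here, compound 2 `CC(C)CCn1ccc(-c2ccc(OCC3CC3)cc2)c(C#N)c1=O` gives 192% in a functional assay on CHO cells for positive allosteric modulation of metabotropic glutamate receptor 2 (Homo sapiens), read by scintillation counting and GTPgammaS binding, with a stated time of 30 min (on this read-out lower numbers stand for smaller maximal responses and higher numbers for larger maximal responses), the higher of the two numbers so far; compound 1 `COc1ccc(-c2ccn(CCC(C)C)c(=O)c2C#N)cc1` gives 160%. Among the compounds with values here, the single step in hand, a number 32 percentage points higher from compound 1 to compound 2 (beyond the scatter), came from a larger group on that oxygen. Compound 3 `CC(C)CCn1ccc(-c2ccc(Oc3ccccc3)cc2)c(C#N)c1=O` differs from compound 2 by phenyl in place of cyclopropylmethyl on an oxygen on an aromatic ring. Within the data shown here, because that step a number 32 percentage points higher from compound 1 to compound 2 (beyond the scatter) was large and upward, a further growth at the same place is expected to keep the response high, although no measured step speaks to an aromatic ring there. Compound 3 is therefore estimated at 185%, between 150% and 215%, a step of a number 7 percentage points lower from compound 2 to compound 3 (within the scatter).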

Compound 3, largest response reached (Emax), in percent of the reference or control that the assay uses: 188%
Estimate against measurement, compound 3: 3 percentage points below; the measured number falls inside the stated range.
By their numbers in this assay, from the lowest: compound 1; then compounds 3 and 2 (each within the scatter of the next).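

At this oxygen on an aromatic ring, an aromatic group serves as well as a non-aromatic one: there is a number 4 percentage points lower from compound 2 to compound 3 (within the scatter) in this assay when phenyl replaces cyclopropylmethyl. The gain over methyl also survives this change of ring, with a number 28 percentage points higher from compound 1 to compound 3 (beyond the scatter), so the rise seen earlier is not confined to cyclopropylmethyl. Nothing available explains why these two groups give such similar responses.

On these data alone, whether an amine, a carboxylic acid or a longer chain on that oxygen would keep the response this high remains open. The compounds shown also leave open whether phenyl would behave the same way on a different core.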